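A Second Chloro Group on Compound 3

The source may hold more compounds than are shown below. What is called first, only, known or untested is meant among the compounds shown, and "the series" means these compounds.

Of the compounds shown here, three have been measured in a functional assay on HCT-116 cells (Homo sapiens) for antiproliferative activity, read by MTT assay, with a stated time of 48 h; on this read-out lower numbers stand for stronger inhibition and higher numbers for weaker inhibition. There, compound 1 `CCCCCCC(CCO)n1cnc2c(Cl)nc(Cl)nc21` gives 12100 nM, compound 2 `CCCCCCCCC(CCO)n1cnc2c(Cl)nc(Cl)nc21` gives 22200 nM and compound 3 `CCCCCCCCCC(CCO)n1cnc2c(Cl)ncnc21` gives 890 nM. That last number is the lowest of the three and lies beyond the scatter of both others.

Compound 4 `CCCCCCCCCC(CCO)n1cnc2c(Cl)nc(Cl)nc21` keeps the chain of compound 3 and alters the core at one place: chloro in place of hydrogen on an aromatic carbon. A chloro group thus takes the place of hydrogen on an aromatic carbon between two ring nitrogen atoms.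

Going by the values given here, no measured step isolates this change. Among the compounds with values here, the only step available, a 1.8-fold higher number from compound 1 to compound 2 (0.26 log units; within the scatter), concerns the chain and stays within the scatter. It gives no sign that chain changes of this kind move the number much. Compound 1 and compound 2 both already carry the chloro group that compound 3 lacks, and both stand well above compound 3 in this assay. A clear upward step is therefore expected, although the chain of compound 4 matches neither of those two, so the whole gap may not appear.

The expected change is a 7.9-fold higher number from compound 3 to compound 4 (0.90 log units; beyond the scatter). For compound 4 the estimated value is 7000 nM, with an expected range from 2000 nM to 25000 nM.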

Compound 4, half-maximal inhibitory concentration: 32600 nM
For compound 4 the middle estimate is 4.7-fold (0.67 log units) below the measured one; measured number outside the range, above it.
By their numbers in this assay, from the lowest: compound 3; then compounds 1, 2 and 4 (each within the scatter of the next, the first and the last beyond it).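

In this assay the chloro group on the aromatic carbon between two ring nitrogen atoms is now seen alone, on an unchanged chain, and it gives a 37-fold higher number from compound 3 to compound 4 (1.56 log units; beyond the scatter) as a large step, so this one position carries much of the gap that separated compound 3 from the other compounds. Among the compounds that carry this chloro group, the chain differences count for far less, with a 1.5-fold higher number from compound 2 to compound 4 (0.17 log units; within the scatter) and with a 2.7-fold higher number from compound 1 to compound 4 (0.43 log units; beyond the scatter) as a modest step, which shows that the longer chain of compound 4 does not bring back the low number of compound 3. No evidence at hand accounts for the size of the step at this carbon.

The compounds shown leave open whether a different group on this aromatic carbon, such as an amine or a methoxy group, would stay near compound 3 or rise towards compound 4. They also leave open whether hydrogen in place of the chloro group at this carbon would bring a step of similar size on the shorter chains of compound 1 and compound 2.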